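A Hydroxy Group Added to Compound 1

The source may report more compounds than this note shows. Statements on the series, on what has been measured and on what is new or still open speak of the compounds shown alone.

Within the data shown here, compound 1 `COc1cc(/C=N/NC(=O)OCc2ccccc2)ccc1O` was tested in a functional assay on cells (Mus musculus) for cytotoxicity, read by MTT assay, with a stated time of 24 h, tested at 10 uM (a higher number here means a stronger effect of the compound at the concentration tested, a lower number a weaker effect), where compound 1 gives 73%, the lower of the two numbers measured so far. Its nearest neighbour is compound 2 `O=C(N/N=C/c1ccc(O)c(O)c1)OCc1ccccc1`, which in this assay gives 84%; the step of a number 11 percentage points higher from compound 1 to compound 2 (beyond the scatter) is modest but beyond the scatter. Compound 3 `COc1cc(/C=N/NC(=O)OCc2ccccc2)c(O)cc1O` has not been measured. It differs from compound 1 in one place: hydroxy in place of hydrogen on an aromatic carbon. Among the measured compounds shown here, no measured step adds a hydroxy group to a ring carbon; the only step known, hydrogen in place of methyl on an oxygen on an aromatic ring, left a hydroxy group where a methoxy group stood and raised the number modestly. On that slim basis the expected step is a number 5 percentage points higher from compound 1 to compound 3 (within the scatter), a small rise or none beyond the scatter. For compound 3 the estimate in this assay is 78%, with a range from 62% to 92%.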

Compound 3, a percentage reported as activity, at one concentration (the size of the read-out at that concentration, not a potency): 79%
Estimate against measurement, compound 3: 1 percentage points below; measured number inside the range.
By their numbers in this assay, from the lowest: compounds 1, 3 and 2 (each within the scatter of the next, the first and the last beyond it).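

In this assay, hydroxy in place of hydrogen on an aromatic carbon gives a number 6 percentage points higher from compound 1 to compound 3 (within the scatter) and so does not clearly separate the two compounds. The earlier step changed only a group on an oxygen, whereas this one shows that the ring carbon ortho to a large group, meta to a hydroxy group and para to a methoxy group can take a hydroxy group with no change beyond the scatter. No measurement shown bears on why this step stays within the scatter.

The compounds shown leave open whether an amine, a carboxylic acid or a longer chain at this same position would give a step beyond the scatter. They also leave open whether the same hydroxy group would give a similar step on the core of compound 2.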